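Iodo to phenyl on a ribosylated bicyclic core in cells

This account rests on a few compounds, and the source may have more. Where it says the series, first, only, none or still open, it means among the compounds named here.

Compound 1 `Cc1nc(N)c2c(-c3ccccc3)cn([C@@H]3O[C@H](CO)[C@@H](O)[C@H]3O)c2n1`: in a functional assay on HCT-116 cells (Homo sapiens), read by MTT assay, with a stated time of 72 h (a higher number here means a weaker inhibitor, a lower number a stronger inhibitor), compound 1 gives > 20000 nM, a limit of the assay.
Compound 2 `Cc1nc(N)c2c(I)cn([C@@H]3O[C@H](CO)[C@@H](O)[C@H]3O)c2n1`: in this assay compound 2 gives > 20000 nM, also a limit.
Compound 3 `CNc1ncnc2c1c(I)cn2[C@@H]1O[C@H](CO)[C@@H](O)[C@H]1O`: in this assay compound 3 gives > 100000 nM, again a limit.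

Compound 1 and compound 2 share one core and differ in one place: phenyl in place of iodo on an aromatic carbon. The step that the two limits leave unreadable from compound 2 to compound 1 cannot be read, because both values sit at the limit of > 20000 nM in this assay, at which 2 of the 3 values shown sit. Compound 3 carries a different core built from the same atoms; the difference between the two cores is not broken down here, and its value sits at the limit of > 100000 nM in this assay, at which 1 of the 3 values shown sits.

Compound 4 `CNc1ncnc2c1c(-c1ccccc1)cn2[C@@H]1O[C@H](CO)[C@@H](O)[C@H]1O` has not been measured. It stands to compound 3 as compound 1 stands to compound 2: phenyl in place of iodo on an aromatic carbon, the same change at the same place. The step from compound 3 to compound 4 is expected to be a number no higher from compound 3 to compound 4 (the limit leaves the size open), and the expectation rests on compound 3 giving > 100000 nM while the same change left compound 1 at > 20000 nM. Compound 4 is therefore expected at roughly 100000 nM, within 20000 nM to 300000 nM, most likely reported only as a limit.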

Compound 4, half-maximal inhibitory concentration: > 100000 nM
Compound 4: only a limit was reported; the forecaster's own chance of this, stated with the estimate: 80%; the middle value sits exactly at the limit.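

No step can be read between compound 3 and compound 4, because both values sit at the same limit of the assay: the limit of > 100000 nM in this assay, at which 2 of the 4 values shown sit. The compounds shown leave open at what concentration any of them would reach the cell read-out's midpoint, and whether phenyl in place of iodo changes anything on either core.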